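Aryl swap on sulfur: compound 2 to compound 4

This account rests on a few compounds, and the source may have more. Where it says the series, first, only, none or still open, it means among the compounds named here.

- compound 1 `Nc1ccccc1NC(=O)c1ccc(CSc2cccc(F)c2)cc1`: 3280 nM
- compound 2 `Cc1ccc(SCc2ccc(C(=O)Nc3ccccc3N)cc2)cc1`: 3740 nM
- compound 3 `Nc1ccccc1NC(=O)/C=C/c1ccc(CSCCc2ccccc2)cc1`: 10900 nM

In a functional assay on SMMC-7721 cells (Homo sapiens) for antiproliferative activity, read by CCK-8 assay, with a stated time of 72 h (on this read-out higher numbers stand for weaker inhibition and lower numbers for stronger inhibition), compound 2 and compound 1 lie within the scatter of each other, while compound 3 gives a higher number than either. Compound 3 differs from both in more than one place, so it offers no direct guide to the change considered here.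

The unmeasured compound 4 `Cc1cc(C)cc(SCc2ccc(C(=O)Nc3ccccc3N)cc2)c1` carries 3,5-dimethylphenyl in place of 4-methylphenyl on a sulfur. Among the compounds with values here, the only measured step at this place is a 1.1-fold higher number from compound 1 to compound 2 (0.06 log units; within the scatter). That step exchanged 3-fluorophenyl for 4-methylphenyl and stayed within the scatter. Within the data shown here, it is a single step, and no measured compound carries 3,5-dimethylphenyl, so the evidence is thin.

On this basis, no step beyond the scatter is expected in this assay. The estimated change is a 1.1-fold lower number from compound 2 to compound 4 (0.03 log units; within the scatter), which means the number is expected to stay close to that of compound 2 at 3740 nM. For compound 4 the expected value is 3500 nM, with an estimated range from 1700 nM to 7200 nM.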

Compound 4, half-maximal inhibitory concentration: 2760 nM
Compound 4: the middle estimate sits 1.3-fold (0.10 log units) above what was measured; the range from low to high includes it.
By their numbers in this assay, from the lowest: compounds 4, 1 and 2 (each within the scatter of the next); then compound 3.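

In this assay, within the data shown here, 3,5-dimethylphenyl in place of 4-methylphenyl on a sulfur gives a 1.4-fold lower number from compound 2 to compound 4 (0.13 log units; within the scatter) and, set against the 3-fluorophenyl group, gives a 1.2-fold lower number from compound 1 to compound 4 (0.07 log units; within the scatter) with no step at this position yet leaving the scatter. The sulfur therefore now carries three different aryl groups within the scatter of each other, including 3,5-dimethylphenyl with 8 heavy atoms against 7 for 4-methylphenyl, so a second methyl group on the ring leaves the number in this assay range unmoved as far as these compounds can tell. No measurement is available that could explain why these numbers stay together.

As far as these compounds go, every aryl group on the sulfur in this set is a carbon-only ring bearing methyl or fluorine, so the response to a pyridine ring, an amine or a carboxylic acid at this place remains open. Compound 3 differs from these compounds in more than one place, so the effect of a longer chain on the sulfur of the shared core also remains unplaced.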